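The compounds below may be only part of what the source reports. "The series", "measured", "known", "first", "only" and "open" are said of these compounds alone.

Compound 1 `COc1cc2c(Nc3ccc(F)c(Cl)c3)ncnc2cc1OCCCCCCn1ccnc1[N+](=O)[O-]`: 6520 nM
Compound 2 `COc1cc2c(Nc3ccc(OCc4cccc(F)c4)c(Cl)c3)ncnc2cc1OCCCCCn1ccnc1[N+](=O)[O-]`: 14400 nM

Both numbers come from a functional assay on A549 cells (Homo sapiens) for inhibition, read by sulforhodamine B assay, with a stated time of 72 h; a lower number here means a stronger inhibitor, a higher number a weaker inhibitor. Compound 2, at 14400 nM, has the higher of the two numbers and is therefore the weaker inhibitor of this pair, and the gap to compound 1 lies beyond the usual scatter. These two compounds differ in more than one place, so their gap cannot be tied to any single change.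

Compound 3 `COc1cc2c(Nc3ccc(OCc4cccc(F)c4)c(Cl)c3)ncnc2cc1OCCCCCCn1ccnc1[N+](=O)[O-]` has not yet been measured. It differs from compound 2 in one place: (2-nitro-1H-imidazol-1-yl)methyl in place of 2-nitro-1H-imidazol-1-yl on a saturated chain carbon, five bonds along the chain from an oxygen on an aromatic ring. Read one bond further out, this is 3-(2-nitro-1H-imidazol-1-yl)propyl changing to 4-(2-nitro-1H-imidazol-1-yl)butyl.

Among the compounds with values here, no measured pair in this assay shows this change alone, so any expectation is uncertain. Compound 3 has the same chain as compound 1 (6520 nM) but differs from it elsewhere, which gives only a faint hint toward a lower number. The expected change is a 1.3-fold lower number from compound 2 to compound 3 (0.12 log units; within the scatter), which is estimated to stay within the scatter. For compound 3 the estimated value is 11000 nM, with an expected range of 5000 nM to 24000 nM.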

Compound 3, half-maximal inhibitory concentration: > 50000 nM
Compound 3 gave a limit, no number (the forecaster's own chance of this, stated with the estimate: 5%); middle value at least 4.5-fold (0.65 log units) away from the limit.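

In this assay, compound 3 gave only a limit, not a number: the limit of > 50000 nM in this assay, at which 1 of the 3 values shown sits.

Changing 3-(2-nitro-1H-imidazol-1-yl)propyl to 4-(2-nitro-1H-imidazol-1-yl)butyl, on a saturated chain carbon five bonds along the chain from an oxygen on an aromatic ring, gives an at least 3.4-fold higher number from compound 2 to compound 3 (0.54 log units; beyond the scatter), so this small extension of the chain is not a neutral change when the rest of the molecule stays the same. The first two compounds could not show this, since they differ in more than one place. With the chain held the same, (3-fluorobenzyl)oxy in place of fluoro on an aromatic carbon gives an at least 7.6-fold higher number from compound 1 to compound 3 (0.88 log units; beyond the scatter), so the weaker result of compound 3 also depends on the group at this second place.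

Because compound 3 gave a limit, the full size of both steps remains unknown, and the compounds shown cannot tell whether the chain change would act the same way in a compound carrying fluoro. They also leave open how a still longer chain, or an amine in place of the 2-nitro-1H-imidazol-1-yl group at the chain end, would read in this assay.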